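Swapping the aryl on the hydrazone carbon: compound 3

A few compounds are considered here, and "the series" means these few. Any claim that something is new, unique, unknown or untested is made for them only; others in the source may bear on it.

Compound 1 `CN(C)CCn1cnnc1-c1cc(Oc2ccc(NC(=O)N/N=C/c3ccc(O)c(Br)c3)cc2F)ccn1`: 450 nM
Compound 2 `COc1ccc(/C=N/NC(=O)Nc2ccc(Oc3ccnc(-c4nncn4CCN(C)C)c3)c(F)c2)cc1O`: 960 nM

In a functional assay on HT-29 cells (Homo sapiens) for cytotoxicity, read by MTT assay, with a stated time of 72 h (on this read-out higher numbers stand for weaker inhibition and lower numbers for stronger inhibition), compound 2 gives the highest of the two numbers; its nearest neighbour is compound 1, where the step is a 2.1-fold higher number from compound 1 to compound 2 (0.33 log units; beyond the scatter). Compound 3 `CN(C)CCn1cnnc1-c1cc(Oc2ccc(NC(=O)N/N=C/c3ccc(F)cc3Cl)cc2F)ccn1` differs from compound 2 only in 2-chloro-4-fluorophenyl in place of 3-hydroxy-4-methoxyphenyl on a carbon with a double bond to nitrogen. Going by the values given here, the one measured step at this place, a 2.1-fold higher number from compound 1 to compound 2 (0.33 log units; beyond the scatter), was modest, and compound 1 carries a halogen on that ring, as compound 3 does. The step from compound 2 to compound 3 is therefore expected to be a 1.6-fold lower number from compound 2 to compound 3 (0.20 log units; within the scatter), towards compound 1. For compound 3 the estimate is 600 nM, within 200 nM to 1800 nM.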

Compound 3, half-maximal inhibitory concentration: 510 nM
For compound 3 the middle estimate is 1.2-fold (0.07 log units) above the measured one, within the range that was stated.
By their numbers in this assay, from the lowest: compounds 1, 3 and 2 (each within the scatter of the next, the first and the last beyond it).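

In this assay, the 2-chloro-4-fluorophenyl ring, with 0 hydrogen-bond donors, cannot be told apart from either earlier ring: a 1.9-fold lower number from compound 2 to compound 3 (0.27 log units; within the scatter) and a 1.1-fold higher number from compound 1 to compound 3 (0.05 log units; within the scatter). A hydroxy group on this ring, present in compound 1 and compound 2, is therefore not required for a number in this range. Nothing measured here explains this result.

As far as these compounds go, what an amine or a carboxylic acid on this ring would give remains open. So does the result of replacing the ring with a simple methyl group.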